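The source may report more compounds than this note shows. Statements on the series, on what has been measured and on what is new or still open speak of the compounds shown alone.

Compound 1 `Cn1cnc2nc(-c3ccc(Cl)cc3)nn2c1=S` carries a methyl group on the shared core; in a functional assay on the whole organism for inhibition, with Rattus norvegicus as the target, at a dose of 3 mg/kg by the intraperitoneal route (a lower number here means less inhibition, a higher number more inhibition at the dose given (going by the name of the read-out)), compound 1 gives 90%. For the measured compounds named here, its only measured neighbour, compound 2 `Cn1cnc2nc(-c3ccc(Cl)c(Cl)c3)nn2c1=S`, gives 89% in this assay, and the step of a number 1 percentage points lower from compound 1 to compound 2 (within the scatter) lies within the scatter, so the two cannot be told apart. Compound 3 `Cc1nc2nc(-c3ccc(Cl)cc3)nn2c(=S)n1C` differs from compound 1 by methyl in place of hydrogen on an aromatic carbon. Going by the values given here, no measured step concerns this change, so nothing points in either direction. Compound 3 is therefore expected to sit near compound 1, with the estimated step of a number 3 percentage points lower from compound 1 to compound 3 (within the scatter) staying within the scatter, at an estimated 87% (range 72% to 97%).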

Compound 3, a percentage reported as inhibition, in the whole organism at one dose (the size of the read-out at that dose, not a potency): 60%
Estimate against measurement, compound 3: 27 percentage points above, outside the stated range (below it).
By their numbers in this assay, from the lowest: compound 3; then compounds 2 and 1 (each within the scatter of the next).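

In this assay methyl in place of hydrogen brings a number 30 percentage points lower from compound 1 to compound 3 (beyond the scatter) and so this aromatic carbon between two ring nitrogen atoms is not a neutral place for substitution. A single added carbon is enough to produce a real difference at this dose, unlike the added chloro of compound 2. Nothing measured here explains the drop.

On these data alone, whether an ethyl group, an amine or a hydroxyl group at this carbon would behave like methyl remains open. So does whether methyl here would have the same effect on the core of compound 2.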